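The source may hold more compounds than are shown below. What is called first, only, known or untested is meant among the compounds shown, and "the series" means these compounds.

Compound 1 `CN(C)C(=O)/C=C1\CCc2ccc(F)cc21`: > 100 mg/kg
Compound 2 `CN(C)C(=O)/C=C1\CCc2c(F)cc(F)cc21`: 50 mg/kg
Compound 3 `Cc1cccc2c1/C(=C/C(N)=O)CC2`: 82 mg/kg

In a functional assay on the whole organism with Mus musculus as the target (on this read-out higher numbers stand for an effect only at larger amounts of compound and lower numbers for an effect already at smaller amounts), compound 1 gives > 100 mg/kg, which is a limit of the assay and not a number. Compound 4 `CCN(C)C(=O)/C=C1\CCc2ccc(F)cc21` differs from compound 1 by methyl in place of hydrogen on a saturated chain carbon bound to an amide-type nitrogen. Among the compounds with values here, the only measured step, an at least 2.0-fold lower number from compound 1 to compound 2 (0.30 log units; that floor lies within the scatter), comes from a different change, fluoro in place of hydrogen on an aromatic carbon, so it offers little guidance. Within the data shown here, no measured step covers the new change, so no shift beyond the scatter is expected. The expected step is a number no higher from compound 1 to compound 4 (the limit leaves the size open). For compound 4 the estimated value is 100 mg/kg, with an expected range from 45 mg/kg to 220 mg/kg.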

Compound 4, dose for half-maximal effect: 100 mg/kg
Estimate against measurement, compound 4: no gap at the digits printed, within the range that was stated.
By their numbers in this assay, from the lowest: compounds 2, 3 and 4 (each within the scatter of the next).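

In this assay, methyl in place of hydrogen on a saturated chain carbon bound to an amide-type nitrogen gives a number no higher from compound 1 to compound 4 (the limit leaves the size open). Unlike the earlier step on an aromatic carbon, this change yields a true number at this place, with compound 4 at 100 mg/kg. The size of the step cannot be read because the value for compound 1 is a limit of the assay: the limit of > 100 mg/kg in this assay, at which 1 of the 4 values shown sits.

Going by these compounds, the effect of a longer chain such as propyl, or of an amine or a carboxylic acid at this place, remains open. So does the result of pairing ethyl(methyl)amino with the added fluoro of compound 2.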